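Series notes: methoxy to hydroxy at compound 4

The compounds below may be only part of what the source reports. "The series", "measured", "known", "first", "only" and "open" are said of these compounds alone.

Measured so far in a functional assay on DU-145 cells (Homo sapiens) for antiproliferative activity, read by luminescence, with a stated time of 96 h; on this read-out higher numbers stand for weaker inhibition and lower numbers for stronger inhibition
- compound 1 `CC1(C)Oc2cc(NS(=O)(=O)c3ccc(F)cc3Cl)ccc2NC1=O` gives 54500 nM
- compound 2 `CC1(C)Oc2cc(NS(=O)(=O)c3ccccc3)ccc2NC1=O` gives 92600 nM
- compound 3 `COc1cc2c(cc1NS(=O)(=O)c1cc(Br)ccc1OC)OC(C)(C)C(=O)N2` gives 23200 nM

In this assay compound 3 gives 23200 nM, the lowest number of the three and beyond the scatter of both compound 1 and compound 2. The next compound is compound 4 `COc1ccc(Br)cc1S(=O)(=O)Nc1cc2c(cc1O)NC(=O)C(C)(C)O2`, and the change is hydrogen in place of methyl on an oxygen on an aromatic ring, or methoxy to hydroxy. Within the data shown here, no measured pair isolates this change. Among the measured compounds shown here, the only measured single-place step is a 1.7-fold higher number from compound 1 to compound 2 (0.23 log units; within the scatter), with phenyl in place of 2-chloro-4-fluorophenyl on a sulfonyl sulfur. That step lies within the scatter and sits at a different place, so it gives only weak guidance on size and none on direction. No step beyond the scatter is therefore expected, and any lean toward a higher number is slight. The expected change is a 1.3-fold higher number from compound 3 to compound 4 (0.11 log units; within the scatter). For compound 4 the estimated value is 30000 nM, with an expected range of 11000 nM to 80000 nM.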

Compound 4, half-maximal inhibitory concentration: 33200 nM
For compound 4 the middle estimate is 1.1-fold (0.04 log units) below the measured one; the measured number falls inside the stated range.
By their numbers in this assay, from the lowest: compounds 3, 4, 1 and 2 (each within the scatter of the next, the first and the last beyond it).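

Among these compounds, removing the methyl from this oxygen, methoxy to hydroxy, gives in this assay a 1.4-fold higher number from compound 3 to compound 4 (0.16 log units; within the scatter) and so provides the first single-place reading at this position. The change stays within the scatter, so compound 3 and compound 4 cannot be told apart here, and a methyl on this oxygen is not needed to keep a number of this size. No supporting data on the origin of this result are available.

Going by these compounds, it remains open how a larger replacement at this place, such as an ethoxy, an amine or a carboxylic acid, would read in this assay. On these data alone, the second methoxy, retained in compound 4, also remains open, as does whether methoxy to hydroxy there would give a step of similar size.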